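This account rests on a few compounds, and the source may have more. Where it says the series, first, only, none or still open, it means among the compounds named here.

Measured compounds:
- Compound 1, `Cc1ccc(-c2nc(CNc3ccc(C(=O)NO)cc3)n(-c3ccccc3)n2)cc1`, in an assay on Sf9 cells for inhibition of protein deacetylase HDAC6 (Homo sapiens), read by fluorescence, with a stated time of 40 min, tested at 100 nM (a lower number here means less inhibition, a higher number more inhibition at the concentration tested (going by the name of the read-out)), gives 62.2%.
- Compound 2, `COc1ccc(-c2nc(CNc3ccc(C(=O)NO)cc3)n(-c3ccccc3)n2)cc1`, in this assay gives 77.6%.
- Compound 3, `O=C(NO)c1ccc(NCc2nc(-c3ccc(Cl)c(Cl)c3)nn2-c2ccccc2)cc1`, in this assay gives 34.5%.

Compound 3 stands lowest of the three in this assay. Its nearest neighbour is compound 1, reached by a number 27.7 percentage points lower from compound 1 to compound 3 (beyond the scatter), and the furthest is compound 2, reached by a number 43.1 percentage points lower from compound 2 to compound 3 (beyond the scatter). Within the two compounds that keep the shared core and differ only at the aryl group on the five-membered ring, a number 15.4 percentage points higher from compound 1 to compound 2 (beyond the scatter) was also seen. All three measured steps therefore concern the aryl group attached to the aromatic carbon between two ring nitrogen atoms, and all three were beyond the scatter.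

Compound 4, `O=C(NO)c1ccc(NCc2nc(-c3ccncc3)nn2-c2ccccc2)cc1`, has not yet been measured in this assay. It differs from compound 3 by pyridin-4-yl in place of 3,4-dichlorophenyl on an aromatic carbon. Going by the values given here, no measured step exchanges an aryl ring for a pyridin-4-yl, so the direction is not fixed by the data; the measured steps only show that this position moves the read-out by modest to large amounts. Compound 4 is expected to show a number 15.5 percentage points higher from compound 3 to compound 4 (beyond the scatter), a step of uncertain direction. The estimate for compound 4 in this assay is 50%, expected to fall between 25% and 75%.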

Compound 4, a percentage reported as inhibition, at one concentration (the size of the read-out at that concentration, not a potency): 30.8%
Compound 4: middle estimate off by 19.2 percentage points, on the high side, within the range that was stated.
By their numbers in this assay, from the lowest: compounds 4 and 3 (each within the scatter of the next); then compound 1; then compound 2.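

In this assay, pyridin-4-yl in place of 3,4-dichlorophenyl on the aromatic carbon between two ring nitrogen atoms gave a number 3.7 percentage points lower from compound 3 to compound 4 (within the scatter), so this exchange, unlike every earlier step at this position, stayed within the scatter, and a ring with a hetero atom and a carbon-only ring bearing two chlorine atoms could not be told apart. The same pyridin-4-yl stood well apart from the two groups with a single substituent on a phenyl ring, with a number 31.4 percentage points lower from compound 1 to compound 4 (beyond the scatter) and a number 46.8 percentage points lower from compound 2 to compound 4 (beyond the scatter), which shows that the two higher readings are not shared by every aryl group tried here and that the large gaps now separate two pairs of compounds. The measured compounds carry no information on why these groups fall into two such pairs.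

The compounds shown leave open whether an unsubstituted phenyl or a 4-hydroxyphenyl at this carbon would read with compound 1 and compound 2 or with compound 3 and compound 4. They also leave open whether a pyridin-3-yl, with its ring nitrogen placed differently, would read with compound 4.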